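Notes on a trifluoromethyl swap at compound 3

A few compounds are considered here, and "the series" means these few. Any claim that something is new, unique, unknown or untested is made for them only; others in the source may bear on it.

Of the compounds shown here, three have been measured in a functional assay on VCaP cells (Homo sapiens) for antiproliferative activity, read by propidium iodide staining, with a stated time of 96 h; a higher number here means a weaker inhibitor, a lower number a stronger inhibitor. Compound 1 (`CC(O)(CSc1cccc(S(F)(F)(F)(F)F)c1)C(=O)Nc1ccc([N+](=O)[O-])c(C(F)(F)F)c1`) gives 9800 nM, compound 2 (`CC(O)(CSc1ccc(S(F)(F)(F)(F)F)cc1)C(=O)Nc1ccc(S(F)(F)(F)(F)F)cc1`) gives 28000 nM, and compound 3 (`CC(O)(CSc1cccc(S(F)(F)(F)(F)F)c1)C(=O)Nc1cccc(S(F)(F)(F)(F)F)c1`) gives 29000 nM. Compound 3 stands level with compound 2, the gap between them lying within the scatter. Compound 1 gives a lower number than compound 3, and that gap lies beyond the scatter. Among the compounds with values here, these three compounds differ in more than one place, so no single-change step is available as a guide.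

Compound 4 (`CC(O)(CSc1cccc(C(F)(F)F)c1)C(=O)Nc1cccc(S(F)(F)(F)(F)F)c1`) departs from compound 3 in one place: a group of 4 heavy atoms (1 carbon, 3 fluorine; no ring) in place of a group of 6 heavy atoms (5 fluorine, 1 sulfur; no ring), on an aromatic carbon. Trifluoromethyl takes the place of the group of 6 heavy atoms on an aromatic carbon, and the rest of the structure stays the same. Within the data shown here, no measured pair shows this exchange, so the expectation is loose. Compound 1, at 9800 nM, shows only that the series can reach numbers lower than those of compound 3. In this assay a small move towards a lower number is expected, probably within the scatter. The expected size of the change is a 1.5-fold lower number from compound 3 to compound 4 (0.16 log units; within the scatter). For compound 4 the estimated value is 20000 nM, with an estimated range of 8000 nM to 40000 nM.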

Compound 4, half-maximal inhibitory concentration: 20200 nM
Beside the measured number, compound 4's estimate is 1.0-fold (0.00 log units) below it; the range from low to high includes it.
By their numbers in this assay, from the lowest: compound 1; then compounds 4, 2 and 3 (each within the scatter of the next).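

Within the data shown here, the first single-change step reads a 1.4-fold lower number from compound 3 to compound 4 (0.16 log units; within the scatter) in this assay. At this place, on an aromatic carbon of a six-membered aromatic ring of carbon only and meta to a large group, trifluoromethyl with its 4 heavy atoms and the group of 6 heavy atoms (5 fluorine, 1 sulfur) cannot be told apart in this read-out, so the exchange neither opens nor closes a gap beyond the scatter. No accompanying measurement bears on this step, and the data give no account of what lies behind it.

Still open, going by these compounds, is whether a different group on this carbon, such as a nitrile, a methoxy group or an amine, would move the number beyond the scatter, and whether the same exchange on the ring that still carries the group of 6 heavy atoms in compound 4 would read the same. The lower number of compound 1 at 9800 nM also stays unassigned, as that compound differs from the others in more than one place.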